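This account rests on a few compounds, and the source may have more. Where it says the series, first, only, none or still open, it means among the compounds named here.

Measured so far:
compound 1 `CSC[C@H]1O[C@@H](n2cnc3c(N)nc(F)nc32)[C@H](OC(C)=O)[C@@H]1OC(C)=O` — 15000 nM
compound 2 `CSC[C@H]1O[C@@H](n2cnc3c(N)nc(Cl)nc32)[C@H](OC(C)=O)[C@@H]1OC(C)=O` — 216000 nM
compound 3 `CC(=O)NC[C@H]1O[C@@H](n2cnc3c(N)nc(F)nc32)[C@H](O)[C@@H]1O` — 182000 nM

In an ADME assay on L6 cells (Rattus norvegicus) for inhibition, read by resazurin assay, with a stated time of 72 h (on this read-out higher numbers stand for weaker inhibition and lower numbers for stronger inhibition), compound 1 gives 15000 nM. Compound 2 differs from it by one change, (chloro in place of fluoro on an aromatic carbon), and the step is a 14-fold higher number from compound 1 to compound 2 (1.16 log units; beyond the scatter). Compound 3 gives 182000 nM in this assay; the difference between its core and the core of compound 1 is not broken down here. Compound 4 `CC(=O)NC[C@H]1O[C@@H](n2cnc3c(N)nc(Cl)nc32)[C@H](O)[C@@H]1O` is not yet measured. It differs from compound 3 by chloro in place of fluoro on an aromatic carbon, the same change already seen from compound 1 to compound 2 at the same place. The step expected here is a 2.7-fold higher number from compound 3 to compound 4 (0.44 log units; beyond the scatter), resting on a 14-fold higher number from compound 1 to compound 2 (1.16 log units; beyond the scatter), though compound 3 already starts at a high number, so this assay may only report a limit. Compound 4 is expected to give about 500000 nM, between 150000 nM and 3000000 nM.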

Compound 4, half-maximal inhibitory concentration: 189000 nM
Estimate against measurement, compound 4: 2.6-fold (0.42 log units) above, and the stated range covers the measured number.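

In this assay, putting chloro in place of fluoro gives a 1.0-fold higher number from compound 3 to compound 4 (0.02 log units; within the scatter), so on this core the change has no readable effect. The size of the step therefore does not carry over from one core to the other: the same change on two cores in this assay, a 14-fold higher number (1.16 log units; beyond the scatter) from compound 1 to compound 2 and a 1.0-fold higher number (0.02 log units; within the scatter) from compound 3 to compound 4, 14-fold (1.14 log units) apart, beyond the scatter of two such steps. This shows that a step seen on one core cannot simply be added to another in this series, but two pairs do not show what sets the size of the step on a given core.

From the compounds shown here alone, it remains open which of the differences between the two cores matters. Also open, going by these compounds, is how a bromo group or an amine on the same aromatic carbon would read on either core.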